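The source may report more compounds than this note shows. Statements on the series, on what has been measured and on what is new or still open speak of the compounds shown alone.

In an assay for inhibition of 15-hydroxyprostaglandin dehydrogenase [NAD(+)] (Homo sapiens), read by fluorescence, with a stated time of 15 min, in the presence of a further agent that is not named here (a lower number here means a stronger inhibitor, a higher number a weaker inhibitor), compound 1 `CCCC[S+]([O-])c1sc2nc(-c3nccs3)cc(-c3ccc(C(=O)OC)cc3)c2c1N` gives 15.1 nM, the lowest of the two numbers recorded in this series. The nearest measured neighbour is compound 3 `CCCCS(=O)(=O)c1sc2nc(-c3nccs3)cc(-c3cnc(C)n3C)c2c1N`, which in this assay gives 32 nM, a gap that lies beyond the usual scatter of repeated measurements. Compound 2 `Nc1c(C(=O)O)sc2nc(-c3cccs3)cc(-c3ccccc3)c12` is different in kind: in this assay compound 2 returns only a limit, > 7500 nM, so that the entry is a boundary of the assay rather than a number, a situation summarised by the limit of > 7500 nM in this assay, at which 1 of the 3 values shown sits.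

The step under consideration leads from compound 1 to compound 4 `CCCC[S+]([O-])c1sc2nc(-c3nccs3)cc(-c3ccc(CNC(C)=O)cc3)c2c1N`. The change is acetamidomethyl in place of methoxycarbonyl on an aromatic carbon. Both groups that leave and enter are small, sit on the same aromatic carbon of a six-membered carbon-only ring, para to a large group, and differ chiefly in how their hydrogen-bond donors and acceptors are counted. Among the measured compounds shown here, no measured pair in the set shows such a change in isolation, so the expectation rests on the shared core and on the value of compound 1 alone.

For compound 4 a modest weakening is expected, a step of a 2.0-fold higher number from compound 1 to compound 4 (0.30 log units; within the scatter) in this assay, near the edge of the scatter rather than well beyond it. Compound 4 is therefore estimated to give 30 nM in this assay, with a likely range from 8 nM to 120 nM.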

Compound 4, half-maximal inhibitory concentration: 2.5 nM
Estimate against measurement, compound 4: 12-fold (1.08 log units) above; the whole stated range lies above it.
By their numbers in this assay, from the lowest: compound 4; then compound 1; then compound 3. At a limit, above all of these: compound 2.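

In this assay, among the compounds shown here, acetamidomethyl in place of methoxycarbonyl gives a 6.0-fold lower number from compound 1 to compound 4 (0.78 log units; beyond the scatter), the first change at a single place that can be read directly. It shows that this aromatic carbon of a six-membered aromatic ring of carbon only, para to a large group, is not indifferent to what it carries, and that the ester of compound 1 can give way to a larger amide-bearing chain with no loss in this assay. The entering group has 1 hydrogen-bond donor and the leaving group 0, but this single pair cannot show whether that difference accounts for the step, and nothing measured here bears on the cause of the step.

The compounds shown leave open whether the amide hydrogen, the carbonyl or the added chain length carries the step, a question that an aminomethyl group or a carboxylic acid on this same carbon would bear on directly. They also leave open whether the same change would give a step of similar size if another part of the shared core were different.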